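Sulfonyl versus carbamoyl at the aromatic carbon of the core

This account rests on a few compounds, and the source may have more. Where it says the series, first, only, none or still open, it means among the compounds named here.

Measured compounds:
compound 1 `Cn1c(=O)c(S(=O)(=O)c2ccc(F)cc2[N+](=O)[O-])cc2cnc(Nc3ccc4[nH]ccc4c3)nc21` — 900 nM
compound 2 `Cn1c(=O)c(S(=O)(=O)c2ccc(O)cc2)cc2cnc(Nc3ccc4[nH]ccc4c3)nc21` — 100 nM
compound 3 `Cn1c(=O)c(C(=O)Nc2ccc(F)cc2)cc2cnc(Nc3ccc4[nH]ccc4c3)nc21` — 5000 nM

In a functional assay on K562 cells (Homo sapiens) for inhibition, read by trypan blue exclusion, with a stated time of 72 h (on this read-out higher numbers stand for weaker inhibition and lower numbers for stronger inhibition), compound 3 gives the highest number of the three, with the step of a 50-fold higher number from compound 2 to compound 3 (1.70 log units; beyond the scatter) being the largest in the set. Compound 4 `Cn1c(=O)c(S(=O)(=O)c2ccc(N)cc2F)cc2cnc(Nc3ccc4[nH]ccc4c3)nc21` differs from compound 3 by (4-amino-2-fluorophenyl)sulfonyl in place of (4-fluorophenyl)carbamoyl on an aromatic carbon. For the measured compounds named here, two measured steps bear on this change: the step of a 50-fold higher number from compound 2 to compound 3 (1.70 log units; beyond the scatter), which goes in the reverse direction of the present move, and the step of a 9.0-fold lower number from compound 1 to compound 2 (0.95 log units; beyond the scatter), which shows how much the ring on the sulfonyl sulfur matters. A large step downward is therefore expected in this assay, placing compound 4 between compound 1 and compound 2. For compound 4 the expected step is a 17-fold lower number from compound 3 to compound 4 (1.22 log units; beyond the scatter). Compound 4 is estimated at 300 nM, within 80 nM to 1200 nM.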

Compound 4, half-maximal inhibitory concentration: 1500 nM
Compound 4: middle estimate off by 5.0-fold (0.70 log units), on the low side; the measured number lies above the stated range.
By their numbers in this assay, from the lowest: compound 2; then compounds 1 and 4 (each within the scatter of the next); then compound 3.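

In this assay the change from carbamoyl to sulfonyl gives only a 3.3-fold lower number from compound 3 to compound 4 (0.52 log units; beyond the scatter) here, so the sulfonyl link alone does not secure a low number. The ring on the sulfur weighs more: a 15-fold higher number from compound 2 to compound 4 (1.18 log units; beyond the scatter) sets 4-hydroxyphenyl apart, while a 1.7-fold higher number from compound 1 to compound 4 (0.22 log units; within the scatter) leaves 4-amino-2-fluorophenyl and 4-fluoro-2-nitrophenyl unresolved. Nothing on hand accounts for these differences.

Open, from the compounds shown here alone, is whether the hydroxyl or the missing ring fluorine goes with the low number of compound 2, which a 4-aminophenyl on the sulfonyl sulfur would help separate. Also open, going by these compounds, is how a (4-hydroxyphenyl)carbamoyl group would compare with (4-hydroxyphenyl)sulfonyl on the same carbon.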